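Swapping one aryl group in a cytotoxicity series

A few compounds are considered here, and "the series" means these few. Any claim that something is new, unique, unknown or untested is made for them only; others in the source may bear on it.

Compound 1 `COc1cccc(/C=C2\CCC/C(=C\c3cccc(Cl)c3Cl)C2=O)c1OC` gives > 20000 nM (a limit, not a number)
Compound 2 `COc1cc(/C=C2\CCC/C(=C\c3cccc(OC)c3OC)C2=O)cc(OC)c1` gives 10200 nM
Compound 3 `COc1ccc(/C=C2\CCC/C(=C\c3cccc(Cl)c3)C2=O)cc1OC` gives 11000 nM

These results come from a functional assay on A549 cells (Homo sapiens) for cytotoxicity, read by MTT assay, with a stated time of 72 h; on this read-out higher numbers stand for weaker inhibition and lower numbers for stronger inhibition. Compound 1 sits at a limit of the assay, > 20000 nM, and this is not a number. Compound 3, at 11000 nM, and compound 2, at 10200 nM, lie within the usual scatter of each other, so the two cannot be ranked.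

Compound 4 `COc1ccc(/C=C2\CCC/C(=C\c3ccc(OC)c(OC)c3)C2=O)cc1` has not yet been measured. It differs from compound 3 in one place, with 4-methoxyphenyl in place of 3-chlorophenyl on a double-bonded chain carbon bound to a double-bonded ring carbon. Going by the values given here, no measured pair of compounds shows a single change of this kind, so the expectation has only the numbers to rest on: compound 2 gives 10200 nM and compound 3 gives 11000 nM. On that basis, no step beyond the scatter is expected in this assay, in either direction. The expected change is a 1.1-fold higher number from compound 3 to compound 4 (0.04 log units; within the scatter). Compound 4 could also reach (the limit of > 20000 nM in this assay, at which 1 of the 3 values shown sits). Compound 4 is estimated at 12000 nM, with an expected range from 5000 nM to 20000 nM.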

Compound 4, half-maximal inhibitory concentration: > 20000 nM
Compound 4 ended at the assay's limit; the forecaster's own chance of this, stated with the estimate: 20%; middle value at least 1.6-fold (0.22 log units) away from the limit.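

Going by these compounds alone, this is the first pair in the set that differs in one place, so it is the first direct reading of a change at this position: in this assay, putting 4-methoxyphenyl in place of 3-chlorophenyl on a double-bonded chain carbon bound to a double-bonded ring carbon gives an at least 1.8-fold higher number from compound 3 to compound 4 (0.25 log units; that floor lies within the scatter). The floor of that step is all that can be stated, so the change shows no gain in inhibition, while the full size of any loss stays hidden. Compound 4 has no exact number here, only a limit of the assay: the limit of > 20000 nM in this assay, at which 2 of the 4 values shown sit.

The pair cannot separate the loss of the chlorine from the arrival of the methoxy group, since both happen in the same swap, and nothing shown tells which of the two matters more at this position. A plain phenyl group there would help to pull these apart, and an amine or a carboxylic acid on that phenyl would show whether this position tolerates anything very different from the chlorine and methoxy groups seen so far.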